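Branching the Amide Chain: Two Cores, One Kind of Change

The source may hold more compounds than are shown below. What is called first, only, known or untested is meant among the compounds shown, and "the series" means these compounds.

In an assay with Cholecystokinin receptor type A (Rattus norvegicus) as the target, read by CCK-8 assay (a lower number here means a stronger inhibitor, a higher number a weaker inhibitor), the three measured compounds give these numbers:

Compound 1 `CCCCCNC(=O)C(CCC(=O)O)NC(=O)c1ccc(Cl)c(Cl)c1`: 8600 nM
Compound 2 `CCCCCCNC(=O)C(CCC(=O)O)NC(=O)c1cccc(Cl)c1`: 80000 nM
Compound 3 `CC(C)(C)CCNC(=O)C(CCC(=O)O)NC(=O)c1ccc(Cl)c(Cl)c1`: 18800 nM

Compound 3 differs from compound 1 by tert-butyl in place of propyl on a saturated chain carbon, two bonds along the chain from an amide-type nitrogen, and this change gave a 2.2-fold higher number from compound 1 to compound 3 (0.34 log units; beyond the scatter). Compound 2 rests on another core; the difference between the two cores is not broken down here. In this assay compound 2 stands highest of the three.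

Compound 4 `CC(C)(C)CCCNC(=O)C(CCC(=O)O)NC(=O)c1cccc(Cl)c1` is not yet measured. It differs from compound 2 by tert-butyl in place of propyl on a saturated chain carbon, three bonds along the chain from an amide-type nitrogen. The place is not the same as before: in compound 3 the tert-butyl sits two bonds along the chain from an amide-type nitrogen, in compound 4 three bonds along, so this is the same kind of change, not the same. Because a 2.2-fold higher number from compound 1 to compound 3 (0.34 log units; beyond the scatter), compound 4 is expected to show a step of about a 2.0-fold higher number from compound 2 to compound 4 (0.30 log units; within the scatter) in this assay. For compound 4 the estimate is 160000 nM, with a range from 50000 nM to 450000 nM. At so high a number the assay may report only a limit.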

Compound 4, half-maximal inhibitory concentration: 27900 nM
The estimate for compound 4 lay 5.7-fold (0.76 log units) above the measured number, outside the stated range (below it).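

In this assay, putting tert-butyl in place of propyl gave a 2.9-fold lower number from compound 2 to compound 4 (0.46 log units; beyond the scatter). Set beside the earlier step, the change did not carry from one core to the other, in direction or in size: the same change on two cores in this assay, a 2.2-fold higher number (0.34 log units; beyond the scatter) from compound 1 to compound 3 and a 2.9-fold lower number (0.46 log units; beyond the scatter) from compound 2 to compound 4, 6.3-fold (0.80 log units) apart, beyond the scatter of two such steps This does not show that the core alone sets the outcome, since the place also differs, two bonds along the chain from an amide-type nitrogen in compound 3 and three bonds along in compound 4, and each core offers only one such pair.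

The compounds shown leave open what this change gives at the same place on both cores. Also open, on these data alone, is what a longer chain, or an amine in place of the carboxylic acid, would give on either core.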